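A few compounds are considered here, and "the series" means these few. Any claim that something is new, unique, unknown or untested is made for them only; others in the source may bear on it.

Measured compounds in a functional assay on U-937 cells (Homo sapiens) for cytotoxicity, read by MTT assay, with a stated time of 48 h; a lower number here means a stronger inhibitor, a higher number a weaker inhibitor:
Compound 1, `Fc1cccc(-c2nc(Nc3ccccc3)c3cc(F)ccc3n2)c1`, gives 45500 nM in this assay.
Compound 2, `COc1ccccc1Nc1nc(-c2cccc(F)c2)nc2ccc(F)cc12`, reaches only the assay limit, > 50000 nM, in this assay.
Compound 3, `Fc1cccc(-c2nc(Nc3ccccc3Cl)c3cc(F)ccc3n2)c1`, likewise reaches only the assay limit, > 50000 nM, in this assay.

Going by the values given here, compound 1 holds the only numerical value; the other two results are limits, as summed up by the limit of > 50000 nM in this assay, at which 2 of the 3 values shown sit. The step from compound 1 to compound 2 is an at least 1.0-fold higher number from compound 1 to compound 2 (0.04 log units; that floor lies within the scatter), and the step from compound 1 to compound 3 is an at least 1.0-fold higher number from compound 1 to compound 3 (0.04 log units; that floor lies within the scatter). The step from compound 2 to compound 3 is a step that the two limits leave unreadable from compound 2 to compound 3.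

Compound 4, `Oc1cccc(Nc2nc(-c3cccc(F)c3)nc3ccc(F)cc23)c1`, differs from compound 1 by hydroxy in place of hydrogen on an aromatic carbon. Among the compounds with values here, both measured steps that add a group to the anilino ring, from compound 1 to compound 2 and from compound 1 to compound 3, ran from the single number toward the limit, so only their floors are readable and both floors lie within the scatter. On that basis no step beyond the scatter is expected for compound 4, with a weakening toward the limit as the more likely side.

Compound 4 is therefore expected at 50000 nM, within 25000 nM to 100000 nM. That estimate means an expected step of a 1.1-fold higher number from compound 1 to compound 4 (0.04 log units; within the scatter).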

Compound 4, half-maximal inhibitory concentration: > 50000 nM
Compound 4: only a limit was reported; the forecaster's own chance of this, stated with the estimate: 55%; the middle value sits exactly at the limit.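

In this assay, going from the 2-methoxyphenyl and 2-chlorophenyl groups to 3-hydroxyphenyl shows that a group at a second place on the ring, meta to a large group, also ends at a limit and gives no number, with an at least 1.0-fold higher number from compound 1 to compound 4 (0.04 log units; that floor lies within the scatter). The steps to compound 4 from compound 2 and from compound 3 join two limits and cannot be read, so hydroxy, methoxy and chloro cannot be ordered against one another. Going by these compounds alone, compound 1, which carries none of these groups on its anilino ring, remains the only compound with a number, and the series now rests mostly on a single limit: the limit of > 50000 nM in this assay, at which 3 of the 4 values shown sit.

From the compounds shown here alone, whether any group on this ring can bring the value under that limit stays open, and so does the true size of each of these changes. Also open, going by these compounds, is what an amine or a carboxylic acid would give at the place held by hydroxy in compound 4, and what hydroxy would give at the place held by methoxy in compound 2.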